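A few compounds are considered here, and "the series" means these few. Any claim that something is new, unique, unknown or untested is made for them only; others in the source may bear on it.

The study centres on a shared core examined in a functional assay for inhibition, with Homo sapiens as the target; a higher number here means a weaker inhibitor, a lower number a stronger inhibitor. Compound 1, `CCCc1nc(C)c2c(CC)nnc(SC)n12`, is one of three measured compounds. In this assay compound 1 gives > 48000 nM, which is a limit of the assay and not a number. Compound 2, `CCCc1nc(C)c2cnnc(SC)n12`, differs from compound 1 by a single change: ethyl in place of hydrogen on an aromatic carbon. In this assay compound 2 gives > 48000 nM, again a limit rather than a number. The step that the two limits leave unreadable from compound 2 to compound 1 therefore cannot be read, because the limit of > 48000 nM in this assay, at which 3 of the 3 values shown sit, leaves both ends of it unresolved. Compound 3, `CCc1nc(C)c2cnnc(O)n12`, has a core whose difference from that of compound 2 is not broken down here. In this assay compound 3 gives > 48000 nM, once more a limit and not a number.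

Compound 4, `CCc1nnc(O)n2c(CC)nc(C)c12`, has not yet been measured. It differs from compound 3 by ethyl in place of hydrogen on an aromatic carbon. For the measured compounds named here, this is the same kind of change as the one from compound 2 to compound 1, but not the same: in compound 1 the ethyl enters para to a methylsulfanyl group, whereas in compound 4 it enters para to a hydroxy group. Since every measured value sits at the limit, as the limit of > 48000 nM in this assay, at which 3 of the 3 values shown sit, shows, no size is readable for this change anywhere in the set. Compound 4 is expected to behave like its neighbours, with an estimated step that the limit leaves unreadable from compound 3 to compound 4 that is small. In this assay compound 4 is estimated at 80000 nM, most likely reported only as a limit, within a range from 30000 nM to 300000 nM.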

Compound 4, half-maximal inhibitory concentration: 24000 nM
Compound 4: the middle estimate sits 3.3-fold (0.52 log units) above what was measured; the measured number lies below the stated range.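

In this assay, for the compounds shown here, compound 4 gives 24000 nM as the only value in the set that is a number. Ethyl in place of hydrogen on an aromatic carbon, para to a hydroxy group, produces an at least 2.0-fold lower number from compound 3 to compound 4 (0.30 log units; that floor lies within the scatter) and so sets only a floor on the step: the true size may be larger, but the readable part does not go beyond the scatter and does not on its own establish a real gain. Nor does the result show that the change carries from one core to another, since on the core of compound 2, with methylsulfanyl in place of hydroxy and para to the entering ethyl, the same change cannot be read, because both of its ends rest on a limit: the limit of > 48000 nM in this assay, at which 3 of the 4 values shown sit.

The compounds shown leave open whether a longer chain such as butyl, or an amine or a carboxylic acid, at that same aromatic carbon would move the number further in either direction. They also leave open how large the ethyl step really is on either core, and whether its size depends on the hydroxy group.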